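A few compounds are considered here, and "the series" means these few. Any claim that something is new, unique, unknown or untested is made for them only; others in the source may bear on it.

Three compounds have a reading in an ADME assay on ECV-304 cells (Homo sapiens) for cytotoxicity, read by MTT assay, with a stated time of 72 h (on this read-out lower numbers stand for stronger inhibition and higher numbers for weaker inhibition), so far. Compound 1 `COc1ccc(C2=C(c3cc(OC)c(OC)c(OC)c3)C(=O)C(O)C2)cc1F` gives 19.5 ug/mL there. Compound 2 `COc1cc(C2=C(c3ccc(SC)cc3)CC(O[SiH2]C(C)(C)C)C2=O)cc(OC)c1OC` reads > 100 ug/mL as a limit of the assay. Compound 3 `CC(=O)OC1C/C(=N/O)C(c2ccccc2)=C1c1ccccc1` likewise reads > 100 ug/mL as a limit and not a number. It thus stands at the limit of > 100 ug/mL in this assay, at which 2 of the 3 values shown sit, and has no firmer position. Compound 4 `O/N=C1/CC(O)C(c2ccccc2)=C1c1ccccc1` differs from compound 3 in one place (hydrogen in place of acetyl on an oxygen on a saturated carbon): hydrogen in place of acetyl on an oxygen on a saturated carbon, acetoxy to hydroxy. Compound 1 also carries a hydroxy on a saturated carbon and gives 19.5 ug/mL but its other groups differ, so only a small move toward stronger inhibition is expected, perhaps none beyond the scatter. The estimate amounts to an at least 1.2-fold lower number from compound 3 to compound 4 (0.09 log units; that floor lies within the scatter) as an expected step. Compound 4 is expected at 80 ug/mL with 30 ug/mL to 200 ug/mL as its estimated range.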

Compound 4, half-maximal inhibitory concentration: > 100 ug/mL
Compound 4: no number, only a limit; the forecaster's own chance of this, stated with the estimate: 55%; middle value at least 1.2-fold (0.09 log units) from the limit.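

Compound 3 and compound 4 both read only as a limit and not as a number, so no step can be read between them: the limit of > 100 ug/mL in this assay, at which 3 of the 4 values shown sit. Going by these compounds, whether acetoxy to hydroxy shifts the reading at all stays open.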